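Acetyl on the phenol oxygen and cell viability

A few compounds are considered here, and "the series" means these few. Any claim that something is new, unique, unknown or untested is made for them only; others in the source may bear on it.

Two compounds sharing one core were tested in an ADME assay on HEK-293T cells (Homo sapiens) for cytotoxicity, read by MTT assay, tested at 25 uM; a higher number here means a weaker effect of the compound at the concentration tested, a lower number a stronger effect. Compound 1 `CC(=O)Oc1cc(Cl)ccc1C(=O)Nc1ncc([N+](=O)[O-])s1` gives 100% in this assay, a value meaning the treated cells look as viable as untreated ones. Compound 2 `O=C(Nc1ncc([N+](=O)[O-])s1)c1cc(Cl)ccc1O` gives 100% in this assay, level with compound 1 at the digits shown; the two values lie within the usual scatter of each other, so no order can be drawn between them. Compound 2 thus stands at the top of the scale, where no effect on the cells is seen.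

For the measured compounds named here, compound 3 `CC(=O)Oc1ccc(Cl)cc1C(=O)Nc1ncc([N+](=O)[O-])s1` differs from compound 2 in one place: acetyl in place of hydrogen on an oxygen on an aromatic ring No pair of measured compounds shows exactly this change, so the step must be estimated. Compound 1 carries an acetyl on an oxygen on an aromatic ring and gives 100%, while compound 2, with hydrogen there, gives 100%, so both ends of this assay's scale seen so far are the same. For compound 3 the expected step is no change at the digits printed from compound 2 to compound 3 (within the scatter), none beyond the scatter. Compound 3 is therefore expected to give 100% in this assay, within a range from 88% to 108%.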

Compound 3, a percentage reported as activity, at one concentration (the size of the read-out at that concentration, not a potency): 59.5%
The estimate for compound 3 lay 40.5 percentage points above the measured number; measured number outside the range, below it.
By their numbers in this assay, from the lowest: compound 3; then compounds 1 and 2 (each within the scatter of the next).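

In this assay, putting acetyl in place of hydrogen on the oxygen on the aromatic ring gives a number 40.5 percentage points lower from compound 2 to compound 3 (beyond the scatter), so on this scaffold the hydroxy to acetoxy change does affect the cells. The acetyl alone does not settle the reading: compound 1 also carries an acetyl on such an oxygen and gives 100%, while compound 3 gives 59.5%, and these two isomers differ in where the chlorine stands on the ring. Nothing available here explains why the number falls with this change or why the place of the chlorine appears to matter.

The compounds shown leave open how the hydroxy partner of compound 1 would read, so the effect of the acetyl in that chlorine arrangement has no direct step to stand on. They also leave open whether the fall in this assay is special to acetyl or would also come with a methyl or a longer acyl chain such as propionyl on the same oxygen.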